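Thiophene Amide to Fluorophenyl Urea on a Shared Core

This account rests on a few compounds, and the source may have more. Where it says the series, first, only, none or still open, it means among the compounds named here.

Of the compounds shown here, three with a shared core have been measured in an assay for binding affinity to 5-hydroxytryptamine receptor 1D (Homo sapiens), read by radioligand binding; on this read-out lower numbers stand for stronger inhibition and higher numbers for weaker inhibition. Compound 1 `CN1CCC(c2c[nH]c3ccc(NC(=O)C4CC4)nc23)CC1` gives 1800 nM, compound 2 `CN1CCC(c2c[nH]c3ccc(NC(=O)c4ccc(C#N)cc4)nc23)CC1` gives 380 nM, and compound 3 `CN1CCC(c2c[nH]c3ccc(NC(=O)c4cccs4)nc23)CC1` gives 650 nM. The steps were a 4.7-fold lower number from compound 1 to compound 2 (0.68 log units; beyond the scatter) and a 2.8-fold lower number from compound 1 to compound 3 (0.44 log units; beyond the scatter), while a 1.7-fold higher number from compound 2 to compound 3 (0.23 log units; within the scatter). The number for compound 3 is thus the second highest of the three, with compound 2 within the scatter of it and compound 1 beyond. Compound 4 `CN1CCC(c2c[nH]c3ccc(NC(=O)Nc4ccc(F)cc4)nc23)CC1` differs from compound 3 by (4-fluorophenyl)amino in place of thiophen-2-yl on a carbonyl carbon. Going by the values given here, no measured step covers an amino group entering on the carbonyl carbon; the two steps involving compound 1 only show that aromatic groups there gave lower numbers than cyclopropyl. In this assay the expected step is a 1.2-fold lower number from compound 3 to compound 4 (0.07 log units; within the scatter), small and uncertain, likely not beyond the scatter. Compound 4 is estimated at 550 nM, within 150 nM to 2000 nM.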

Compound 4, inhibition constant: 3.8 nM
Compound 4: middle estimate off by 140-fold (2.16 log units), on the high side; measured number below the stated range.
By their numbers in this assay, from the lowest: compound 4; then compounds 2 and 3 (each within the scatter of the next); then compound 1.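

Far larger than any step among the earlier groups, (4-fluorophenyl)amino on the carbonyl carbon brings a 170-fold lower number from compound 3 to compound 4 (2.23 log units; beyond the scatter) along with a 100-fold lower number from compound 2 to compound 4 (2.00 log units; beyond the scatter) and also a 470-fold lower number from compound 1 to compound 4 (2.68 log units; beyond the scatter) and so the group at this position can move the number much further than cyclopropyl, 4-cyanophenyl and thiophen-2-yl suggested. The entering group differs from thiophen-2-yl in both its ring and its added amino hydrogen. No available evidence explains the size of this step.

From the compounds shown here alone, it remains open whether the amino link or the fluorinated ring accounts for the drop. Plain phenylamino and 4-fluorophenyl attached directly to the carbonyl carbon would help separate the two.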